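Acid to Amide on a Longer Chain: An Expectation

A few compounds are considered here, and "the series" means these few. Any claim that something is new, unique, unknown or untested is made for them only; others in the source may bear on it.

Measured so far:
compound 1, `O=C(O)CCCCCn1nc(-c2ccccc2)c(-c2ccccc2)c1-c1ccccc1` — > 78000 nM
compound 2, `O=C(O)CCCCCCCCn1cc(-c2ccccc2)cn1` — > 105000 nM

Both compounds were tested in a functional assay for inhibition, with Homo sapiens as the target; a lower number here means a stronger inhibitor, a higher number a weaker inhibitor. For compound 1 the result > 78000 nM is a limit of the assay and not a number. For compound 2 the result > 105000 nM is likewise a limit and not a number. Compound 1 therefore cannot be placed on a scale against compound 2: the two values show only that neither gave a measurable inhibition, as the limit of > 78000 nM in this assay, at which 1 of the 2 values shown sits, and the limit of > 105000 nM in this assay, at which 1 of the 2 values shown sits, record.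

Compound 3, `NC(=O)CCCCCCCCn1nc(-c2ccccc2)c(-c2ccccc2)c1-c1ccccc1`, is not yet measured. It differs from compound 1 in one place: 3-carbamoylpropyl in place of carboxy on a saturated chain carbon, five bonds along the chain from an aromatic nitrogen.

Going by the values given here, no measured pair with a comparable change exists here, so the expected step from compound 1 to compound 3 in this assay rests only on the two limits. A change in either direction beyond the scatter is not expected. The step that the limit leaves unreadable from compound 1 to compound 3 is thus estimated as essentially flat. Compound 3 is expected to give 100000 nM, within 30000 nM to 300000 nM, most likely again reported only as a limit.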

Compound 3, half-maximal inhibitory concentration: 33000 nM
Beside the measured number, compound 3's estimate is 3.0-fold (0.48 log units) above it; low and high end bracket the measured number.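

Placing 3-carbamoylpropyl where carboxy stood, on a saturated chain carbon, five bonds along the chain from an aromatic nitrogen, gives in this assay an at least 2.3-fold lower number from compound 1 to compound 3 (0.37 log units; beyond the scatter). Going by these compounds alone, compound 3 gives 33000 nM, the first value in this set that is a number and not a limit, so the core shared with compound 1 can show measurable inhibition once this end of the chain is changed. The size of the step is only a minimum because the value of compound 1 is a limit of the assay: the limit of > 78000 nM in this assay, at which 1 of the 3 values shown sits.

This single change ends the chain in a different group and also makes it longer, so the two compounds cannot tell which of these two differences carries the step; a carboxylic acid on the longer chain of compound 3, or an amide on the shorter chain of compound 1, would separate them. On these data alone, whether an amine or a nitrile at the end of the longer chain would give a similar number also remains open.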